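A Chloro Substituent Repeated on a Second Core

The source may report more compounds than this note shows. Statements on the series, on what has been measured and on what is new or still open speak of the compounds shown alone.

Compound 1 `O=c1c(SC(=S)N2CCCCC2)coc2ccccc12` is the starting point. In a functional assay on MDA-MB-435S cells (Homo sapiens) for antiproliferative activity, read by MTT assay, with a stated time of 72 h (on this read-out lower numbers stand for stronger inhibition and higher numbers for weaker inhibition), compound 1 gives 17400 nM. Compound 2 `O=c1c(SC(=S)N2CCCCC2)coc2ccc(Cl)cc12` carries chloro in place of hydrogen on an aromatic carbon; in this assay compound 2 gives 13300 nM, and the step is a 1.3-fold lower number from compound 1 to compound 2 (0.12 log units; within the scatter), so the two values are essentially indistinguishable. Compound 3 `CC(C)N(C(=S)SCc1coc2ccccc2c1=O)C(C)C` is built on a different core; the difference between the two cores is not broken down here. In this assay compound 3 gives 7900 nM, a number whose gap to compound 2 lies within the scatter while its gap to compound 1 lies beyond it. Compound 4 `CC(C)N(C(=S)SCc1coc2cc(Cl)ccc2c1=O)C(C)C` has not been measured yet; it differs from compound 3 by chloro in place of hydrogen on an aromatic carbon, the same change already seen between compound 1 and compound 2, at a place described in exactly the same words. The expected step of a 1.2-fold lower number from compound 3 to compound 4 (0.08 log units; within the scatter) is set beside the earlier one and rests on a 1.3-fold lower number from compound 1 to compound 2 (0.12 log units; within the scatter), which barely moved the number. Compound 4 is therefore expected at about 6500 nM, with a likely range from 2500 nM to 17000 nM.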

Compound 4, half-maximal inhibitory concentration: > 25000 nM
Compound 4: only a limit was reported; the forecaster's own chance of this, stated with the estimate: 5%; at least 3.8-fold (0.58 log units) between middle value and limit.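

Going by these compounds alone, on the second core, chloro in place of hydrogen on an aromatic carbon gives an at least 3.1-fold higher number from compound 3 to compound 4 (0.50 log units; beyond the scatter) in this assay, a clear loss of inhibition that has no counterpart on the first core. The change therefore does not carry over unaltered from one core to the other: the same change on two cores in this assay, a 1.3-fold lower number (0.12 log units; within the scatter) from compound 1 to compound 2 and an at least 3.1-fold higher number (0.50 log units; beyond the scatter) from compound 3 to compound 4, at least 4.1-fold (0.61 log units) apart, beyond the scatter of two such steps. Compound 4 gives > 25000 nM, which is a limit and not a number, so the true size of this step stays unknown, and a single pair on each core shows neither why the cores differ nor any rule for the wider series: the limit of > 25000 nM in this assay, at which 1 of the 4 values shown sits.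

The compounds shown leave open whether fluoro, bromo or methoxy at the same place would behave as chloro does on each core. They also leave open whether the gap between the cores would remain if a morpholine replaced the amine part of the side chain.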